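This account rests on a few compounds, and the source may have more. Where it says the series, first, only, none or still open, it means among the compounds named here.

Measured so far:
compound 1 `Cc1nc(S(C)(=O)=O)ccc1Oc1ncnc(OC2CCN(C(=O)OC3COC3)CC2)c1F` gives 2500 nM in a functional assay on isolated protein for inhibition of Glucose-dependent insulinotropic receptor (Rattus norvegicus), read by HTRF and cAMP accumulation; on this read-out lower numbers stand for an effect already at smaller amounts and higher numbers for an effect only at larger amounts of compound;
compound 2 `Cc1nc(S(C)(=O)=O)ccc1Oc1ncnc(OC2CCN(C(=O)SC3(C)CC3)CC2)c1F` gives 166 nM in this assay.

On the two numbers available, compound 2 stands at the lower end: the step of a 15-fold lower number from compound 1 to compound 2 (1.18 log units; beyond the scatter) is large and well beyond the scatter, so compound 2 is the more potent of the two measured compounds. That step exchanged a four-membered oxygen-containing ring on the carbonyl carbon for a sulfur-linked three-membered carbon ring.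

Compound 3 `Cc1nc(S(C)(=O)=O)ccc1Oc1ncnc(OC2CCN(C(=S)OC(C)C)CC2)c1F` has not yet been measured in this assay. It differs from compound 2 by a group of 6 heavy atoms (4 carbon, 1 oxygen, 1 sulfur; no ring) in place of a group of 7 heavy atoms (5 carbon, 1 oxygen, 1 sulfur; one three-membered non-aromatic ring of carbon only), on an amine nitrogen in a ring. Among the compounds with values here, only one measured step exists, the one from compound 1 to compound 2, and it concerns a different part of the same attachment, so it bears on the new change only loosely. The three-membered ring that helped in that step is lost in compound 3, while the sulfur is kept, now as a double-bonded atom. The expected effect is therefore a moderate weakening rather than a large one, with a 2.1-fold higher number from compound 2 to compound 3 (0.32 log units; beyond the scatter) as the estimated step. For compound 3 the estimate in this assay is 350 nM, with a range from 90 nM to 1400 nM.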

Compound 3, half-maximal effective concentration: 1050 nM
For compound 3 the middle estimate is 3.0-fold (0.48 log units) below the measured one, within the range that was stated.
By their numbers in this assay, from the lowest: compound 2; then compound 3; then compound 1.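

In this assay, the group on the amine nitrogen in the six-membered ring proves sensitive to a second kind of change: giving up the group with the three-membered carbon ring for the ring-free group that carries its sulfur as a double-bonded atom gives a 6.3-fold higher number from compound 2 to compound 3 (0.80 log units; beyond the scatter). Keeping a sulfur atom in this group is therefore not enough to hold the low number of compound 2. The ring-free group still improves on the group with the four-membered oxygen-containing ring, with a 2.4-fold lower number from compound 1 to compound 3 (0.38 log units; beyond the scatter), so compound 3 falls between the other two and the data give no explanation for this order.

Because the ring, the position of the sulfur and the double bond all change together on going to compound 3, the three compounds cannot show which of these differences matters most. Also open, going by these compounds, is how this assay would respond at this position to a tert-butyl group, a longer carbon chain or a basic amine.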